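The source may hold more compounds than are shown below. What is called first, only, known or untested is meant among the compounds shown, and "the series" means these compounds.

Working notes on the benzyloxy series. In a functional assay on HT-29 cells (Homo sapiens) for inhibition, read by MTT assay, with a stated time of 48 h (on this read-out higher numbers stand for weaker inhibition and lower numbers for stronger inhibition), compound 1 `Cc1ccc(NC(=S)NC(=O)c2ccc(OCc3ccccc3)cc2)cc1-c1nc2ccccc2[nH]1` gives 28800 nM. Its trifluoromethyl analogue, compound 2 `Cc1ccc(NC(=S)NC(=O)c2ccc(OCc3cccc(C(F)(F)F)c3)cc2)cc1-c1nc2ccccc2[nH]1`, gives 8200 nM in this assay, and the step of a 3.5-fold lower number from compound 1 to compound 2 (0.55 log units; beyond the scatter) is the only one measured so far. Compound 2 therefore stands at the lowest of the two numbers, its nearest neighbour being compound 1.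

Compound 3 `Cc1ccc(NC(=S)NC(=O)c2ccc(OCc3ccccc3F)cc2)cc1-c1nc2ccccc2[nH]1` differs from compound 2 by 2-fluorophenyl in place of 3-(trifluoromethyl)phenyl on a saturated chain carbon bound to an oxygen on an aromatic ring. Among the compounds with values here, the one step that bears on this is a 3.5-fold lower number from compound 1 to compound 2 (0.55 log units; beyond the scatter), which shows that adding trifluoromethyl on that ring lowered the number by a modest amount; compound 3 removes that group and carries only a single fluorine on the ring in its place. Within the data shown here, the expectation is that part of that gain is lost and the number moves back toward compound 1, a step of a 2.1-fold higher number from compound 2 to compound 3 (0.32 log units; beyond the scatter), though a fluorine-bearing ring has no measured precedent here. Compound 3 is estimated at 17000 nM in this assay, with a range of 7000 nM to 40000 nM.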

Compound 3, half-maximal inhibitory concentration: 1870 nM
For compound 3 the middle estimate is 9.1-fold (0.96 log units) above the measured one; measured number outside the range, below it.
By their numbers in this assay, from the lowest: compound 3; then compound 2; then compound 1.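

In this assay the trifluoromethyl group is not needed for a lower number on this ring: fluoro in place of hydrogen gives a 15-fold lower number from compound 1 to compound 3 (1.19 log units; beyond the scatter) and exceeds the step with trifluoromethyl, a 3.5-fold lower number from compound 1 to compound 2 (0.55 log units; beyond the scatter) in the same assay. Exchanging 3-(trifluoromethyl)phenyl for 2-fluorophenyl on the saturated chain carbon bound to an oxygen on an aromatic ring gives a 4.4-fold lower number from compound 2 to compound 3 (0.64 log units; beyond the scatter) and places compound 3 lowest of the three, with its steps to both others beyond the scatter. No available evidence accounts for this order.

Compound 2 and compound 3 differ in both the group and its place on the ring, so the share of each in the step cannot be separated. On these data alone, whether chlorine, methoxy or a nitrile on this ring would follow fluoro or trifluoromethyl also remains open.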